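A few compounds are considered here, and "the series" means these few. Any claim that something is new, unique, unknown or untested is made for them only; others in the source may bear on it.

Working notes on the series. Within the data shown here, in a functional assay on SEM cells (Homo sapiens) for cytotoxicity, with a stated time of 72 h (on this read-out higher numbers stand for an effect only at larger amounts of compound and lower numbers for an effect already at smaller amounts), compound 1 (`C=C[C@@](C)(/C=C/c1ccc(O)c(/C=C/C(=O)c2ccccc2)c1)CCC=C(C)C`) gives 8000 nM, the only true number so far. Compound 2 (`CCOC(=O)/C(C)=C/c1cc(/C=C/[C@](C)(/C=C/c2ccc(OC)cc2)CCC=C(C)C)ccc1O`) reports only a limit, > 36600 nM. Compound 3 (`COc1ccc(/C=C/[C@@](C)(/C=C/c2ccc(O)c(/C=C/C(=O)OC(C)(C)C)c2)CCC=C(C)C)cc1`) also reports only a limit, > 36600 nM. Compound 3 therefore has no number and stands at the limit of > 36600 nM in this assay, at which 2 of the 3 values shown sit. Among the measured compounds shown here, the one measured step is a step that the two limits leave unreadable from compound 2 to compound 3, so it offers no size to carry forward.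

Compound 4 (`COc1ccc(/C=C/[C@@](C)(/C=C/c2ccc(O)c(/C=C/C(=O)c3ccccc3)c2)CCC=C(C)C)cc1`) has phenyl in place of tert-butoxy on a carbonyl carbon. This turns 2-(tert-butoxycarbonyl)ethenyl into 2-benzoylethenyl. For the measured compounds named here, the sole guide is compound 1, which also carries 2-benzoylethenyl and gives 8000 nM, although it differs from compound 4 elsewhere. A move toward lower numbers in this assay is therefore expected, of uncertain size, and another limit remains possible. The expected change is an at least 3.0-fold lower number from compound 3 to compound 4 (0.48 log units; beyond the scatter). For compound 4 the estimated value is 12000 nM, with an expected range of 4000 nM to 36600 nM.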

Compound 4, half-maximal effective concentration: 36600 nM
Beside the measured number, compound 4's estimate is 3.1-fold (0.48 log units) below it, within the range that was stated.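

Phenyl on the carbonyl carbon gives a true number in this assay, where compound 4 reaches 36600 nM, so this series now has a second measured value. The first readable step is a 4.6-fold higher number from compound 1 to compound 4 (0.66 log units; beyond the scatter), with 2-(4-methoxyphenyl)ethenyl in place of vinyl on the saturated chain carbon while 2-benzoylethenyl stays the same. The change to 2-benzoylethenyl in place of 2-(ethoxycarbonyl)prop-1-en-1-yl on an aromatic carbon gives a number no higher from compound 2 to compound 4 (the limit leaves the size open). Compound 2 and compound 3 remain limits, and their steps to compound 4 cannot be read in size: the limit of > 36600 nM in this assay, at which 2 of the 4 values shown sit.

Phenyl in place of tert-butoxy gives a number no higher from compound 3 to compound 4 (the limit leaves the size open), so how much of a change it brings, if any, is open, as is whether an amine or a hydroxyl on the same carbonyl carbon would give a number. Also open, as far as these compounds go, is whether a longer chain in place of vinyl would keep the lower number of compound 1.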